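Esters of the chalcone core: expected inertness of compound 4

This account rests on a few compounds, and the source may have more. Where it says the series, first, only, none or still open, it means among the compounds named here.

Measured compounds, with an assay on HEK293T cells for inhibition of nuclear factor NF-kappa-B complex (Homo sapiens), read by a luciferase reporter (on this read-out higher numbers stand for weaker inhibition and lower numbers for stronger inhibition), values:
compound 1 `CCCCC(=O)Oc1ccc(/C=C/C(=O)c2c(OC)cc3c(c2O)CCC(C)(C)O3)cc1` — its value is a limit of the assay: > 30000 nM
compound 2 `COc1cc2c(c(O)c1C(=O)/C=C/c1ccc(OC(=O)c3ccccc3F)cc1)CCC(C)(C)O2` — its value is a limit of the assay: > 30000 nM
compound 3 `C=CCOC(=O)Oc1ccc(/C=C/C(=O)c2c(OC)cc3c(c2O)CCC(C)(C)O3)cc1` — its value is a limit of the assay: > 30000 nM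

Compound 3 stands at the same limit as every other measured member of the series; no number separates it from compound 1 or compound 2. The three measured steps, a step that the two limits leave unreadable from compound 1 to compound 2, a step that the two limits leave unreadable from compound 1 to compound 3 and a step that the two limits leave unreadable from compound 2 to compound 3, cannot be sized, since all values sit at the limit (the limit of > 30000 nM in this assay, at which 3 of the 3 values shown sit).

Compound 4 `COc1cc2c(c(O)c1C(=O)/C=C/c1ccc(OC(=O)c3cccc(Br)c3)cc1)CCC(C)(C)O2` differs from compound 3 by 3-bromophenyl in place of allyloxy on a carbonyl carbon. Within the data shown here, the only measured step that bears on this change is the one from a butyl or allyloxy chain to an aromatic ring on that carbonyl carbon; compound 2 carries 2-fluorophenyl there and gives only a limit. On that basis no step beyond the limit is expected in this assay: the step from compound 3 to compound 4 is estimated as a step that the limit leaves unreadable from compound 3 to compound 4, with the assay most likely reporting a limit again. Compound 4 is therefore expected to give about 60000 nM, in the range 15000 nM to 300000 nM.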

Compound 4, half-maximal inhibitory concentration: > 30000 nM
Compound 4 gave a limit, no number; the forecaster's own chance of this, stated with the estimate: 85%; the middle value is on the limit's open side.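

In this assay compound 4 gives > 30000 nM, a limit of the assay and not a number. No step linking compound 4 with compound 1, compound 2 or compound 3 can be read: the limit of > 30000 nM in this assay, at which 4 of the 4 values shown sit.

The compounds shown leave open whether any group on this carbonyl carbon brings inhibition into the measurable range.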